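Pyrazolyl chalcones: swapping the aminophenyl for dichlorophenyl

The compounds below may be only part of what the source reports. "The series", "measured", "known", "first", "only" and "open" are said of these compounds alone.

The series shares a methoxylated aryl-pyrazole core joined through a propenone to a second aryl ring. Compound 1 `COc1cc(-c2cc(/C=C/C(=O)c3ccc(N)cc3)[nH]n2)cc(OC)c1OC` carries a 4-aminophenyl on the carbonyl carbon; in a functional assay on 786-0 cells (Homo sapiens) for cytotoxicity, read by sulforhodamine B assay, with a stated time of 48 h, tested at 100 uM (on this read-out lower numbers stand for a stronger effect and higher numbers for a weaker effect at the one concentration tested), compound 1 gives -90%. Compound 2 `COc1ccc(-c2cc(/C=C/C(=O)c3ccc(OC)c(OC)c3)[nH]n2)cc1` carries a 3,4-dimethoxyphenyl there and in this assay compound 2 gives -96%. Of the two numbers, compound 1 shows the higher one, but the gap to compound 2 lies within the usual scatter, so the two cannot be ordered.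

Compound 3 `COc1cc(-c2cc(/C=C/C(=O)c3ccc(Cl)c(Cl)c3)[nH]n2)cc(OC)c1OC` differs from compound 1 in one place: 3,4-dichlorophenyl in place of 4-aminophenyl on a carbonyl carbon. Going by the values given here, both measured values sit near the floor of the read-out, and no comparison between measured compounds is available to calibrate this change. The step from compound 1 to compound 3 is therefore expected to be small, a number 2 percentage points higher from compound 1 to compound 3 (within the scatter), with no direction beyond the scatter. Compound 3 is estimated at -88%, within -100% to -60%.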

Compound 3, a percentage reported as activity, at one concentration (the size of the read-out at that concentration, not a potency): -10%
Beside the measured number, compound 3's estimate is 78 percentage points below it; the whole stated range lies below it.
By their numbers in this assay, from the lowest: compounds 2 and 1 (each within the scatter of the next); then compound 3.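

Replacing 4-aminophenyl with 3,4-dichlorophenyl on a carbonyl carbon gives a number 80 percentage points higher from compound 1 to compound 3 (beyond the scatter) in this assay, a much weaker effect at the one concentration tested. This shows that, with the core of compound 1 held constant, the read-out is highly sensitive to the group at this position. Compound 1 and compound 2 differ in more than one place and lie within the scatter of each other, so they could not show this sensitivity. No measurement available here bears on the reason for the step.

The compounds shown leave open whether the step follows from the departure of the amino group or the arrival of the two chlorines. A plain phenyl, a 4-chlorophenyl or a 4-hydroxyphenyl on the core of compound 1 would help separate those two parts of the change.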